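Removing the tert-butyl from compound 2

The source may report more compounds than this note shows. Statements on the series, on what has been measured and on what is new or still open speak of the compounds shown alone.

Compound 1 `C/C(=C\c1csc(C)n1)[C@@H]1C[C@@H]2OC(c3ccccc3)=N[C@H]2CCC[C@H](C)[C@H](O)[C@@H](C)C(=O)C(C)(C)[C@@H](O)CC(=O)O1` gives 19.2 nM in a functional assay on MCF7 cells (Homo sapiens) for antiproliferative activity, with a stated time of 72 h (on this read-out lower numbers stand for stronger inhibition and higher numbers for weaker inhibition), as the reference point. Compound 2 `C/C(=C\c1csc(C)n1)[C@@H]1C[C@@H]2OC(c3ccc(C(C)(C)C)cc3)=N[C@H]2CCC[C@H](C)[C@H](O)[C@@H](C)C(=O)C(C)(C)[C@@H](O)CC(=O)O1` sits at > 10000 nM in this assay and that is a limit, not a number. Going by the values given here, the one measured step bearing on the next change is an at least 520-fold higher number from compound 1 to compound 2 (2.71 log units; beyond the scatter) and it is large. Among the compounds with values here, compound 3 `C/C(=C\c1csc(C)n1)[C@@H]1C[C@@H]2OC(c3cccnc3)=N[C@H]2CCC[C@H](C)[C@H](O)[C@@H](C)C(=O)C(C)(C)[C@@H](O)CC(=O)O1` has pyridin-3-yl in place of 4-(tert-butyl)phenyl (pyridin-3-yl in place of 4-(tert-butyl)phenyl on a carbon with a double bond to nitrogen) so the tert-butyl of that step is gone, while no measured step covers the entering nitrogen. A large move toward lower numbers is therefore expected, with an at least 250-fold lower number from compound 2 to compound 3 (2.39 log units; beyond the scatter) as the estimated step. In this assay the expected value for compound 3 is 40 nM within a range of 8 nM to 300 nM as estimated here.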

Compound 3, half-maximal inhibitory concentration: 1.3 nM
For compound 3 the middle estimate is 31-fold (1.49 log units) above the measured one; measured number below the stated range.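

Here the ring at this position can gain as well as lose: pyridin-3-yl in place of phenyl gives a 15-fold lower number from compound 1 to compound 3 (1.17 log units; beyond the scatter), so a ring nitrogen takes the number below that of the unsubstituted phenyl. Pyridin-3-yl in place of 4-(tert-butyl)phenyl gives an at least 7600-fold lower number from compound 2 to compound 3 (3.88 log units; beyond the scatter), a size that is only a bound. Compound 2 stands at a limit, not a number: the limit of > 10000 nM in this assay, at which 1 of the 3 values shown sits.

Whether the ring nitrogen must sit where it does in pyridin-3-yl stays open, since pyridin-2-yl and pyridin-4-yl are not among these compounds. Also open, from the compounds shown here alone, is how a group smaller than tert-butyl, such as methyl, would fare on the phenyl ring.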